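Removing Fluorine from the Aryl Ring in Two Core Series

A few compounds are considered here, and "the series" means these few. Any claim that something is new, unique, unknown or untested is made for them only; others in the source may bear on it.

Compound 1: `COc1cc(OC)cc(N2CCN(C(=O)c3onc(C)c3-c3ccccc3F)CC2)c1`, 165 nM
Compound 2: `Cc1ccc(C)c(N2CCN(C(=O)c3oc(C)nc3-c3ccc(F)cc3)CC2)c1`, 358 nM
Compound 3: `Cc1ccc(C)c(N2CCN(C(=O)c3oc(C)nc3-c3ccccc3)CC2)c1`, 31.3 nM

All three numbers come from a functional assay on HL-60 cells (Homo sapiens) for inhibition, read by MTT assay, with a stated time of 72 h; a higher number here means a weaker inhibitor, a lower number a stronger inhibitor. Compound 2 and compound 3 share a core and differ in one place: hydrogen in place of fluoro on an aromatic carbon. That change gave an 11-fold lower number from compound 2 to compound 3 (1.06 log units; beyond the scatter). Compound 1 belongs to a different core; the difference between the two cores is not broken down here. In this assay compound 1 stands beyond the scatter from both compound 2 and compound 3, with compound 3 giving the lowest number of the three.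

Compound 4, `COc1cc(OC)cc(N2CCN(C(=O)c3onc(C)c3-c3ccccc3)CC2)c1`, has not been measured. It differs from compound 1 in one place: hydrogen in place of fluoro on an aromatic carbon. Among the compounds with values here, this is the same kind of change as the one from compound 2 to compound 3, not the same: there the fluoro sat para to a large group, here it sits ortho to a large group, and the cores differ.

Within the data shown here, because the one measured example of this change gave an 11-fold lower number from compound 2 to compound 3 (1.06 log units; beyond the scatter), compound 4 is expected to give a lower number than compound 1, though a step of a 2.8-fold lower number from compound 1 to compound 4 (0.44 log units; beyond the scatter) is the expectation, smaller than that example, since the place and the core are not the same. In this assay compound 4 is estimated at 60 nM, likely between 18 nM and 200 nM.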

Compound 4, half-maximal inhibitory concentration: 152 nM
For compound 4 the middle estimate is 2.5-fold (0.40 log units) below the measured one; measured number inside the range.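

In this assay the same change, 2-fluorophenyl to phenyl, on the core of compound 1 gave a 1.1-fold lower number from compound 1 to compound 4 (0.04 log units; within the scatter) and so did not separate the fluoro compound from its hydrogen counterpart on this core. The large gain seen on the other core therefore did not carry over, and the size of this step depends on the pair in which it is made: the same change on two cores in this assay, an 11-fold lower number (1.06 log units; beyond the scatter) from compound 2 to compound 3 and a 1.1-fold lower number (0.04 log units; within the scatter) from compound 1 to compound 4, 11-fold (1.02 log units) apart, beyond the scatter of two such steps. This does not show why the two steps differ, since the pairs differ both in the core and in where the fluoro stands on the ring, and two pairs cannot separate these two influences or support a rule for any further core.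

The compounds shown leave open what would happen on the core of compound 1 if the fluoro stood elsewhere on the phenyl ring, and what would happen on either core if a chloro group or a hydroxyl group took its place. They also leave open whether a fluoro group ortho to a large group on the core of compound 3 would give a step like the one on the core of compound 1 or a larger one.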